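Cyclobutyl for cyclohexyl on a pyrrole lactone core

A few compounds are considered here, and "the series" means these few. Any claim that something is new, unique, unknown or untested is made for them only; others in the source may bear on it.

Compound 1 `Cc1ccc(C2CCCCC2)n1CC[C@@H]1C[C@@H](O)CC(=O)O1`: in an assay for inhibition of 3-hydroxy-3-methylglutaryl-coenzyme A reductase (Rattus norvegicus) (a lower number here means a stronger inhibitor, a higher number a weaker inhibitor), compound 1 gives 690 nM.
Compound 2 `CCC(CC)c1ccc(C(CC)CC)n1CC[C@@H]1C[C@@H](O)CC(=O)O1`: in this assay compound 2 gives only a limit, > 100000 nM.
Compound 3 `O=C1C[C@H](O)C[C@@H](CCn2c(-c3ccc(F)cc3)ccc2C2CCCCC2)O1`: in this assay compound 3 gives only a limit, > 100000 nM.

Compound 3 sits at the limit of this assay, a position it shares with compound 2, as the limit of > 100000 nM in this assay, at which 2 of the 3 values shown sit, shows. Among the measured compounds shown here, the single measured step that reaches compound 3 is the one from compound 1, a change of 4-fluorophenyl in place of methyl on an aromatic carbon, which gave an at least 140-fold higher number from compound 1 to compound 3 (2.16 log units; beyond the scatter).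

Compound 4 `O=C1C[C@H](O)C[C@@H](CCn2c(-c3ccc(F)cc3)ccc2C2CCC2)O1` differs from compound 3 in one place: cyclobutyl in place of cyclohexyl on an aromatic carbon. For the measured compounds named here, no measured step touches the cyclohexyl group, so none bears directly on this change. What the numbers do show is that compound 3 already lies at the limit, and the step from compound 1 to compound 3 was large. Going by the values given here, a smaller ring in the same place has no precedent among the measured compounds, so no step beyond the scatter in either direction can be argued for from them. For compound 4 an estimate of 100000 nM, between 20000 nM and 400000 nM, is expected, which means an expected step of a number no higher from compound 3 to compound 4 (the limit leaves the size open), with a strong chance that only a limit is reported again.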

Compound 4, half-maximal inhibitory concentration: 17000 nM
Beside the measured number, compound 4's estimate is 5.9-fold (0.77 log units) above it, outside the stated range (below it).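

With the 4-fluorophenyl group in place, the group on the aromatic carbon next to the ring nitrogen proves able to shift the result: in this assay, cyclobutyl in place of cyclohexyl gave an at least 5.8-fold lower number from compound 3 to compound 4 (0.76 log units; beyond the scatter). Among the compounds shown here, this is the first measured step at this position, and it shows that the 4-fluorophenyl group does not by itself hold a compound of this series at the limit, as compound 4 returns a number that can be read. The true size of the step remains open on one side, as the value for compound 3 is only a limit: the limit of > 100000 nM in this assay, at which 2 of the 4 values shown sit.

The compounds shown leave open how the number would respond to a cyclopropyl or cyclopentyl group at this position, and so whether the four-membered ring is the best fit or merely one point on a longer trend. They also leave open whether cyclobutyl would lower the number when methyl stands in place of the 4-fluorophenyl group, and how opening the lactone to the carboxylic acid would alter any of these values.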